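Working notes: compound 4 against three measured analogues

The compounds below may be only part of what the source reports. "The series", "measured", "known", "first", "only" and "open" are said of these compounds alone.

Measured in a functional assay on the whole organism (stomach) with Rattus norvegicus as the target; on this read-out higher numbers stand for an effect only at larger amounts of compound and lower numbers for an effect already at smaller amounts:
- compound 1 `N#CNC(=N)NCCCCCn1nc(-c2ccccc2)ccc1=O`: > 100 mg/kg, a limit of the assay, not a number
- compound 2 `O=c1ccc(-c2ccccc2)nn1CCCCNC(=S)Nc1ccccc1`: > 100 mg/kg, likewise a limit
- compound 3 `CCC/N=C(/NC#N)NCCCCn1nc(-c2ccccc2)ccc1=O`: > 100 mg/kg, likewise a limit

Compound 3 therefore stands at the limit of > 100 mg/kg in this assay, at which 3 of the 3 values shown sit; no ordering among the three is readable. Compound 4 `C=CCNC(=S)NCCCCn1nc(-c2ccccc2)ccc1=O` differs from compound 3 by a group of 6 heavy atoms (4 carbon, 1 nitrogen, 1 sulfur; no ring) in place of a group of 8 heavy atoms (5 carbon, 3 nitrogen; no ring), on an amine nitrogen. Among the measured compounds shown here, the only measured step touching this position, a step that the two limits leave unreadable from compound 2 to compound 3, is unreadable, as both ends are limits. For the measured compounds named here, no measured step bears on the change in a readable way, so no step beyond the scatter can be expected in this assay; the expected step that the limit leaves unreadable from compound 3 to compound 4 is essentially none. Compound 4 is estimated at 150 mg/kg, within 50 mg/kg to 500 mg/kg, most likely reported again as a limit.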

Compound 4, dose for half-maximal effect: > 100 mg/kg
Compound 4: only a limit was reported; the forecaster's own chance of this, stated with the estimate: 75%; the middle value lies beyond the limit too.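

Compound 4 also gives only a limit, so its steps from compound 1, compound 2 and compound 3 cannot be read: the limit of > 100 mg/kg in this assay, at which 4 of the 4 values shown sit.

Still open is how far each compound shown lies beyond that limit, and whether exchanging these groups changes the effect at all.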